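The source may hold more compounds than are shown below. What is called first, only, known or untested is meant among the compounds shown, and "the series" means these compounds.

Compound 1 `CC1=CC[C@@H]2[C@@H](O[C@H](c3ccc(F)cc3)OC2(C)C)[C@@H]1O` gives 40% in a functional assay on the whole organism (Abdomen, strain albino) for inhibition, with Mus musculus as the target, in the writhing test, with stated times of 1 h and 8 min, at a dose of 10 mg/kg by the oral route; a higher number here means more inhibition at the dose given (going by the name of the read-out), a lower number less inhibition.
Compound 2 `CC1=CC[C@@H]2[C@@H](O[C@H](c3ccc(Br)cc3)OC2(C)C)[C@@H]1O` gives 33% in this assay.
Compound 3 `CC1=CC[C@@H]2[C@@H](O[C@H](c3cccc(Cl)c3)OC2(C)C)[C@@H]1O` gives 27% in this assay.

Compound 3 holds the lowest of the three numbers: compound 2 lies nearest, a number 6 percentage points lower from compound 2 to compound 3 (within the scatter), and compound 1 furthest, a number 13 percentage points lower from compound 1 to compound 3 (beyond the scatter). Compound 4 `CC1=CC[C@@H]2[C@@H](O[C@H](c3cccc(F)c3)OC2(C)C)[C@@H]1O` differs from compound 3 by a single change: fluoro in place of chloro on an aromatic carbon. For the measured compounds named here, the only measured step that trades one halogen for another is a number 7 percentage points lower from compound 1 to compound 2 (within the scatter), and it left the number within the scatter. On that basis the step to compound 4 in this assay is expected to stay within the scatter as well, perhaps leaning slightly upward, a number 3 percentage points higher from compound 3 to compound 4 (within the scatter). Compound 4 is therefore estimated at 30%, with a range from 18% to 42%.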

Compound 4, a percentage reported as inhibition, in the whole organism at one dose (the size of the read-out at that dose, not a potency): 40%
Compound 4: middle estimate off by 10 percentage points, on the low side; the range from low to high includes it.
By their numbers in this assay, from the lowest: compounds 3, 2, 1 and 4 (each within the scatter of the next, the first and the last beyond it).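

In this assay, for the compounds shown here, the halogen on this aromatic carbon turns out to matter: a number 13 percentage points higher from compound 3 to compound 4 (beyond the scatter) is the first exchange of one halogen for another to go beyond the scatter. With fluoro in this place, the 3-fluorophenyl group matches the 4-fluorophenyl group, with no change at the digits printed from compound 1 to compound 4 (within the scatter) on that change, while a number 7 percentage points higher from compound 2 to compound 4 (within the scatter) against the 4-bromophenyl group is also no clear difference. Nothing available explains why fluoro and chloro part here. As far as these compounds go, whether a methoxy group or an amine on this carbon would keep the number stays open.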